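The source may report more compounds than this note shows. Statements on the series, on what has been measured and on what is new or still open speak of the compounds shown alone.

Working notes on the series. Compound 2 `O=C(COCc1ccccc1)N1CCN(c2ccc(F)cc2)CC1` carries a 4-fluorophenyl on the ring amine nitrogen; in a functional assay on HEK293 cells for positive allosteric modulation of metabotropic glutamate receptor 5 (Homo sapiens), read by FLIPR and calcium flux (on this read-out lower numbers stand for an effect already at smaller amounts and higher numbers for an effect only at larger amounts of compound), compound 2 gives 1100 nM. Its nearest neighbour is compound 1 `O=C(COCc1ccccc1)N1CCN(c2ccccc2Cl)CC1`, which carries a 2-chlorophenyl in the same place; in this assay compound 1 gives 1100 nM. Within the data shown here, the one measured step, no change at the digits printed from compound 1 to compound 2 (within the scatter), shows that exchanging one aryl pattern for the other left the read-out where it was.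

Compound 3 `O=C(COCc1ccccc1)N1CCN(c2ccc(F)cc2Cl)CC1` is next. The change from compound 2 is chloro in place of hydrogen on an aromatic carbon, so compound 3 unites the chloro of compound 1 with the fluoro of compound 2. Among the measured compounds shown here, the only step that bears on this is the flat one from compound 1 to compound 2; nothing in the data points to either direction. For compound 3 the expected step is no change at the digits printed from compound 2 to compound 3 (within the scatter), none beyond the scatter. Compound 3 is therefore estimated at 1100 nM, in the range 450 nM to 2700 nM.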

Compound 3, half-maximal effective concentration: 270 nM
Compound 3: the middle estimate sits 4.1-fold (0.61 log units) above what was measured, outside the stated range (below it).
By their numbers in this assay, from the lowest: compound 3; then compounds 1 and 2 (each within the scatter of the next).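

On the 4-fluorophenyl, chloro in place of hydrogen, ortho to a large group and meta to the fluoro group, gives a 4.1-fold lower number from compound 2 to compound 3 (0.61 log units; beyond the scatter) in this assay, and adding fluoro to the 2-chlorophenyl gives a 4.1-fold lower number from compound 1 to compound 3 (0.61 log units; beyond the scatter). The flat step, no change at the digits printed from compound 1 to compound 2 (within the scatter), showed only that one single-substituent pattern read like the other; the 2-chloro-4-fluorophenyl now shows that carrying both groups on the same ring separates from either pattern alone. No measurement here bears on what lies behind this step.

The compounds shown leave open whether a methyl or a nitrile in place of the chloro would give the same step. They also leave open where an unsubstituted phenyl would stand against all three patterns on the shared core.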